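Carboxy to ethoxycarbonyl: compound 3 to compound 4

This account rests on a few compounds, and the source may have more. Where it says the series, first, only, none or still open, it means among the compounds named here.

Of the compounds shown here, three have been read so far in an ADME assay on KB cells (Homo sapiens) for cytotoxicity, read by MTT assay, with a stated time of 72 h; on this read-out lower numbers stand for stronger inhibition and higher numbers for weaker inhibition. Compound 1 `COc1ccc(OC)c(C2=C(c3cc(OC)c(OC)c(OC)c3)C(=O)CC2O[SiH2]C(C)(C)C)c1` gives 10 ug/mL.

Compound 2 `COc1ccc(C2=C(c3cc(OC)c(OC)c(OC)c3)C(=O)CC2O)cc1O` reads < 1 ug/mL, which is a limit of the assay.

Compound 3 `COc1cc(C2=C(c3ccc(OCC(=O)O)cc3)C(O)CC2=O)cc(OC)c1OC` reads > 100 ug/mL, which is also a limit of the assay. It stands at the weak end of the three readings in this assay, at the limit of > 100 ug/mL in this assay, at which 1 of the 3 values shown sits.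

Compound 4 `CCOC(=O)COc1ccc(C2=C(c3cc(OC)c(OC)c(OC)c3)C(=O)CC2O)cc1` has not yet been measured. It differs from compound 3 by ethyl in place of hydrogen on an oxygen next to a carbonyl group, so that carboxymethyl becomes (ethoxycarbonyl)methyl. Among the compounds with values here, no measured pair isolates this change, so the size of the step can only be estimated. The expectation leans on compound 1 at 10 ug/mL, which has no carboxy group. A shift toward stronger inhibition, beyond the usual scatter, is therefore expected in this assay. The estimated step is an at least 6.6-fold lower number from compound 3 to compound 4 (0.82 log units; beyond the scatter).

Compound 4 is expected at 15 ug/mL, within an estimated range of 3 ug/mL to 80 ug/mL.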

Compound 4, half-maximal inhibitory concentration: > 100 ug/mL
Compound 4 gave a limit, no number (the forecaster's own chance of this, stated with the estimate: 25%); middle value at least 6.6-fold (0.82 log units) away from the limit.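

In this assay compound 3 reads > 100 ug/mL, a limit. Compound 4 reads > 100 ug/mL, also a limit, and no step can be read between compound 3 and compound 4. The compounds shown leave open whether carboxy and ethoxycarbonyl differ at all in this assay.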